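The source may hold more compounds than are shown below. What is called first, only, known or untested is meant among the compounds shown, and "the series" means these compounds.

Measured so far in a functional assay on RBL cells for antagonist activity at C-X-C chemokine receptor type 1 (Homo sapiens), read by fluorescence and calcium flux, with a stated time of 30 min; on this read-out higher numbers stand for weaker inhibition and lower numbers for stronger inhibition:
compound 1, `O=C(Nc1ccc(F)cc1)c1cnc(NCc2cccc(B(O)O)c2)nc1` — 1340 nM
compound 2, `CN(Cc1cccc(B(O)O)c1)c1ncc(C(=O)Nc2ccc(F)cc2)cn1` — 2500 nM

Compound 1 has the lowest of the two numbers, and its nearest neighbour is compound 2, where the step of a 1.9-fold higher number from compound 1 to compound 2 (0.27 log units; within the scatter) lies within the scatter. Compound 3, `O=C(Nc1ccc(F)cc1)c1cnc(NCc2ccc(B(O)O)cc2)nc1`, differs from compound 1 in the boronic acid bearing ring: a group of 9 heavy atoms (6 carbon, 1 boron, 2 oxygen; one six-membered aromatic ring of carbon only) in place of a group of 9 heavy atoms (6 carbon, 1 boron, 2 oxygen; one six-membered aromatic ring of carbon only), on a saturated chain carbon bound to a nitrogen on an aromatic ring. Among the measured compounds shown here, no measured step changes this ring; the only measured step, from compound 1 to compound 2, alters a different place and was a 1.9-fold higher number from compound 1 to compound 2 (0.27 log units; within the scatter), so it gives no direct guide. The expectation for compound 3 therefore rests on the values of compound 1 and compound 2 alone, and a step of a 1.5-fold higher number from compound 1 to compound 3 (0.17 log units; within the scatter) is expected, that is, no confident movement beyond the scatter. Compound 3 is estimated at 2000 nM, with a range of 500 nM to 8000 nM.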

Compound 3, half-maximal inhibitory concentration: 1700 nM
Compound 3: the middle estimate sits 1.2-fold (0.07 log units) above what was measured, and the stated range covers the measured number.
By their numbers in this assay, from the lowest: compounds 1, 3 and 2 (each within the scatter of the next).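

In this assay, among the compounds shown here, the boronic acid changes its place on the six-membered aromatic ring of carbon only, with the atoms otherwise the same, and this gives a 1.3-fold higher number from compound 1 to compound 3 (0.10 log units; within the scatter) for the first measured change to this ring. Between these two compounds, then, the place of the boronic acid on that ring makes no difference that the assay can separate from the scatter, although this one pair says nothing about other groups on the ring. Nothing available here bears on the reason for this result.

As far as these compounds go, it remains open whether the boronic acid itself matters, since neither compound 1 nor compound 3 shows how a carboxylic acid or an amine on the same ring would compare. A longer chain between this ring and the nitrogen, and changes to the fluorine-bearing ring, also remain untested in the compounds shown.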